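Urea series: difluorophenyl in place of fluorophenyl on the amide nitrogen

The source may report more compounds than this note shows. Statements on the series, on what has been measured and on what is new or still open speak of the compounds shown alone.

Measured so far:
compound 1, `CC(C)(C)c1cc(NC(=O)Nc2ccc(F)cc2)n(-c2ccccc2)n1`: 6.5 degrees C
compound 2, `Cc1ccc(-n2nc(C(C)(C)C)cc2NC(=O)Nc2cc(C(F)(F)F)cc(C(F)(F)F)c2)cc1`: -0.5 degrees C

In an assay on isolated protein for inhibition of serine/threonine-protein kinase 10 (Homo sapiens), read by thermal shift assay, tested at 10 uM (on this read-out lower numbers stand for weaker stabilisation of the target and higher numbers for stronger stabilisation of the target against heat), compound 1 gives 6.5 degrees C and stands highest of the two numbers available. Compound 2 gives -0.5 degrees C in the same assay, a number that lies below compound 1 by more than the scatter. Compound 2 differs from compound 1 at more than one place, so no single-change step can be read from the two values; they show only that the two ends of the series sit far apart.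

Compound 3, `CC(C)(C)c1cc(NC(=O)Nc2cc(F)cc(F)c2)n(-c2ccccc2)n1`, has not yet been measured. It differs from compound 1 by 3,5-difluorophenyl in place of 4-fluorophenyl on an amide-type nitrogen. Among the measured compounds shown here, no measured pair isolates a change of this kind, so the direction of the step is open. The expectation is a step that stays close to the scatter, with the unmeasured side slightly lower than compound 1, written as a number 1.0 degrees C lower from compound 1 to compound 3 (within the scatter). Compound 3 is accordingly estimated at 5.5 degrees C, within the range from 3 degrees C to 8 degrees C.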

Compound 3, shift of the target's melting temperature: 2.5 degrees C
The estimate for compound 3 lay 3.0 degrees C above the measured number; the measured number lies below the stated range.
By their numbers in this assay, from the lowest: compound 2; then compound 3; then compound 1.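

In this assay, among the compounds shown here, 3,5-difluorophenyl in place of 4-fluorophenyl on the amide-type nitrogen gives a number 4.0 degrees C lower from compound 1 to compound 3 (beyond the scatter), the first single-change step that can be read. This position is therefore sensitive to the fluorine substitution of the ring, although compound 3 at 2.5 degrees C still shows stabilisation of the target on the same shared core. The change adds a fluorine and alters the substitution pattern in one step, so the two parts cannot be separated, and no measurement at hand bears on the origin of the step.

Still open, from the compounds shown here alone, is how a plain phenyl, a chlorophenyl or a methoxyphenyl would read on this nitrogen, and such groups could show whether the step follows the number of fluorines or their placement. For the compounds shown here, compound 2 differs from both compound 1 and compound 3 at more than one place, so no step to it can be read and the low value of compound 2 at -0.5 degrees C remains unassigned to any single group.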